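This account rests on a few compounds, and the source may have more. Where it says the series, first, only, none or still open, it means among the compounds named here.

Measured so far in an assay on isolated protein for displacement of a labelled ligand from metabotropic glutamate receptor 5 (Homo sapiens), with a stated time of 60 min, tested at 1 uM; a higher number here means more inhibition at the concentration tested (going by the name of the read-out), a lower number less inhibition:

- compound 1 `COCC1CCN(c2c(S(=O)(=O)c3ccc(F)cc3)cnc3cc(F)ccc23)CC1`: 76.1%
- compound 2 `COCC1CCN(c2c(S(=O)(=O)c3cc(F)cc(F)c3)cnc3cc(F)ccc23)CC1`: 83%
- compound 3 `COCC1CCN(c2c(S(=O)(=O)c3cccc(F)c3)cnc3cc(F)ccc23)CC1`: 70.5%

The three compounds share one core and differ only in the fluorine pattern of the phenyl on the sulfonyl sulfur. Compound 3 holds the lowest of the three numbers, but only one gap separates it clearly from the others: the step of a number 5.6 percentage points lower from compound 1 to compound 3 (within the scatter) stays within the scatter, whereas the step of a number 12.5 percentage points lower from compound 2 to compound 3 (beyond the scatter) lies beyond it. The remaining step, a number 6.9 percentage points higher from compound 1 to compound 2 (within the scatter), is also within the scatter, so the measured range of this set is narrow.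

Compound 4 `COCC1CCN(c2c(S(=O)(=O)c3cccc(C#N)c3)cnc3cc(F)ccc23)CC1` is the next member. It differs from compound 3 by cyano in place of fluoro on an aromatic carbon, that is, 3-fluorophenyl becomes 3-cyanophenyl on the sulfonyl sulfur.

Going by the values given here, no measured step exchanges fluoro for cyano, so nothing in this assay bears directly on the change; the three known steps concern only how many fluorines sit on that ring and where, and only one of them exceeded the scatter. The expected step is therefore a number 1.5 percentage points higher from compound 3 to compound 4 (within the scatter), not clearly beyond the scatter in either direction, with a wide range to reflect the missing precedent. For compound 4 in this assay the estimate is 72%, expected to fall between 52% and 88%.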

Compound 4, a percentage reported as inhibition, at one concentration (the size of the read-out at that concentration, not a potency): 91%
Compound 4: middle estimate off by 19 percentage points, on the low side, outside the stated range (above it).
By their numbers in this assay, from the lowest: compounds 3, 1, 2 and 4 (each within the scatter of the next, the first and the last beyond it).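

Working notes on the series: the position is not limited to fluoro, since in this assay cyano on this aromatic carbon, meta to a large group, gives a number 20.5 percentage points higher from compound 3 to compound 4 (beyond the scatter) and so moves the number further than the change from 3,5-difluorophenyl to 3-fluorophenyl did. The 4-fluorophenyl comparison points the same way, with a number 14.9 percentage points higher from compound 1 to compound 4 (beyond the scatter) on a change of both group and place, whereas a number 8 percentage points higher from compound 2 to compound 4 (within the scatter) leaves 3-cyanophenyl and 3,5-difluorophenyl not separated on this read-out. Nothing available explains why cyano and fluoro differ at this position.

Only fluoro and cyano are shown on this ring, so it remains open whether the rise in this assay is particular to the nitrile or would also appear with a group such as acetyl, methoxy or a carboxylic acid. Also open, on these data alone, are the effect of cyano at the position held by fluoro in compound 1, the outcome of combining cyano with a second fluorine as 3-cyano-5-fluorophenyl, and the size of the effect of compound 4 at other concentrations, which a reading at a single concentration does not give.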